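From Cyano to Ethoxycarbonyl in a Closely Matched Trio

This account rests on a few compounds, and the source may have more. Where it says the series, first, only, none or still open, it means among the compounds named here.

Compound 1 (`N#Cc1c(/N=C/c2ccccc2)sc2c1CCCC2`) gives 20 nM in a functional assay on MCF7 cells (Homo sapiens) for inhibition (on this read-out lower numbers stand for stronger inhibition and higher numbers for weaker inhibition), and compound 2 (`N#Cc1c(/N=C/NNc2ccccc2)sc2c1CCCC2`) gives 30 nM on the same read-out. Compound 3 (`N#Cc1c(/N=C/n2nc(N)cc2O)sc2c1CCCC2`) gives 20 nM there, level with compound 1, and all three numbers sit within the usual scatter. Compound 4 (`CCOC(=O)c1c(/N=C/n2nc(N)cc2O)sc2c1CCCC2`) has ethoxycarbonyl in place of cyano on an aromatic carbon and still awaits measurement. Going by the values given here, no measured pair shows this change, so the expectation is only a judgement: a modest move towards weaker inhibition in this assay that may not clear the scatter. The estimated change is a 2.0-fold higher number from compound 3 to compound 4 (0.30 log units; within the scatter) in this read-out. Compound 4 is estimated at 40 nM with 12 nM to 200 nM as its expected range.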

Compound 4, half-maximal inhibitory concentration: 10 nM
Estimate against measurement, compound 4: 4.0-fold (0.60 log units) above, and the stated range ends above it.
By their numbers in this assay, from the lowest: compounds 4, 1, 3 and 2 (each within the scatter of the next, the first and the last beyond it).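

In this assay, ethoxycarbonyl in place of cyano on this aromatic carbon gives a 2.0-fold lower number from compound 3 to compound 4 (0.30 log units; within the scatter). Going by these compounds alone, this is the first look at a change at this position, and it shows that the larger group, with 5 heavy atoms against 2, leaves the number within the scatter of compound 3. Nothing available explains the result in terms of any measured property.

Still open, going by these compounds, is whether a carboxylic acid or a primary amide on this carbon would stay as close. On these data alone, it is also open whether the same swap would read alike with the side groups of compound 1 or compound 2.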